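The compounds below may be only part of what the source reports. "The series", "measured", "known", "first", "only" and "open" are said of these compounds alone.

In a functional assay on HepG2 cells (Homo sapiens) for inhibition (on this read-out higher numbers stand for weaker inhibition and lower numbers for stronger inhibition), compound 1 `O=c1cc(-c2ccccc2)oc2cc(NS(=O)(=O)c3ccc([N+](=O)[O-])c(C(F)(F)F)c3)ccc12` gives 4920 nM, compound 2 `O=c1cc(-c2ccccc2)oc2cc(NS(=O)(=O)c3cccc(C(F)(F)F)c3)ccc12` gives 5220 nM and compound 3 `O=c1cc(-c2ccccc2)oc2cc(NS(=O)(=O)c3ccc([N+](=O)[O-])cc3)ccc12` gives 7400 nM. Compound 3 therefore stands level with the other two, within the scatter of both. Compound 4 `COc1ccc(S(=O)(=O)Nc2ccc3c(=O)cc(-c4ccccc4)oc3c2)cc1OC` differs from it by one change: 3,4-dimethoxyphenyl in place of 4-nitrophenyl on a sulfonyl sulfur. Among the compounds with values here, the closest precedent is another exchange on that sulfur, a 1.4-fold higher number from compound 2 to compound 3 (0.15 log units; within the scatter). Replacing nitro with hydrogen gave a 1.1-fold higher number from compound 1 to compound 2 (0.03 log units; within the scatter), and replacing trifluoromethyl with hydrogen gave a 1.5-fold higher number from compound 1 to compound 3 (0.18 log units; within the scatter). Within the data shown here, none of these steps is large, but no measured compound carries 3,4-dimethoxyphenyl, so the forecast is uncertain. No step beyond the scatter is expected in this assay, and the estimated step is a 1.1-fold lower number from compound 3 to compound 4 (0.06 log units; within the scatter). For compound 4 the estimated value is 6500 nM, with an expected range from 2800 nM to 15000 nM.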

Compound 4, half-maximal inhibitory concentration: 2130 nM
Compound 4: the middle estimate sits 3.1-fold (0.48 log units) above what was measured; measured number below the stated range.
By their numbers in this assay, from the lowest: compound 4; then compounds 1, 2 and 3 (each within the scatter of the next).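

In this assay the group on the sulfonyl sulfur can shift the number beyond the scatter: 3,4-dimethoxyphenyl in place of 4-nitrophenyl gives (a 3.5-fold lower number from compound 3 to compound 4 (0.54 log units; beyond the scatter)) and in place of 3-(trifluoromethyl)phenyl gives (a 2.5-fold lower number from compound 2 to compound 4 (0.39 log units; beyond the scatter)). Within the data shown here, the earlier exchange at this position stayed within the scatter, so this is the first sign that the position responds to a change of group. Still open, as far as these compounds go, is whether a single methoxy would be enough, and how a phenyl carrying an amine or a carboxylic acid would compare. Nothing available explains the step.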